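The compounds below may be only part of what the source reports. "The series", "measured", "known", "first", "only" and "open" are said of these compounds alone.

In a functional assay on MCF-A cells (Homo sapiens) for cytotoxicity (on this read-out lower numbers stand for stronger inhibition of growth and higher numbers for weaker inhibition of growth), compound 1 `COc1ccc(C2=C(c3cc(OC)c(OC)c(OC)c3)CC3CCCN3C2=O)cc1O` gives > 100000 nM, which is a limit of the assay and not a number. Compound 2 `COc1ccc(C2=C(c3ccc(SC)cc3)CC3CCCN3C2=O)cc1OC(=O)CNC(=O)OC(C)(C)C` gives 6000 nM, and compound 3 `COc1ccc(C2=C(c3ccc(SC)cc3)CC3CCCN3C2=O)cc1OC(=O)C1CCCN1C(=O)OC(C)(C)C` gives 4000 nM. Within the data shown here, compound 2 therefore holds one of only two actual numbers, and it sits within the scatter of compound 3.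

Compound 4 `COc1ccc(C2=C(c3ccc(SC)cc3)CC3CCCN3C2=O)cc1C` departs from compound 2 in one place: one carbon atom in place of a group of 12 heavy atoms (7 carbon, 1 nitrogen, 4 oxygen; no ring), on an aromatic carbon. The methyl stands on an aromatic carbon, ortho to a methoxy group.

Among the measured compounds shown here, only one measured step touches this group, namely a 1.5-fold lower number from compound 2 to compound 3 (0.18 log units; within the scatter). That step alters the group but does not remove it, so it gives neither a size nor a direction for the present change. The expectation therefore stays close to compound 2 at 6000 nM, with a wide margin. No change beyond the scatter is expected, and the estimated step is a 1.2-fold lower number from compound 2 to compound 4 (0.08 log units; within the scatter). Compound 4 is expected at about 5000 nM, with an estimated range from 800 nM to 30000 nM.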

Compound 4, concentration for 50% growth inhibition: 400 nM
For compound 4 the middle estimate is 13-fold (1.10 log units) above the measured one; the measured number lies below the stated range.
By their numbers in this assay, from the lowest: compound 4; then compounds 3 and 2 (each within the scatter of the next). At a limit, above all of these: compound 1.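

In this assay, putting a methyl in place of the large group gave a 15-fold lower number from compound 2 to compound 4 (1.18 log units; beyond the scatter), whereas exchanging one large group for another had given only a 1.5-fold lower number from compound 2 to compound 3 (0.18 log units; within the scatter). The read-out therefore does respond to what stands on this aromatic carbon, and the large group is not needed for inhibition of growth in this series. Compound 1 differs from these compounds in more than one place and its value is a limit, so it gives no step on this change: the limit of > 100000 nM in this assay, at which 1 of the 4 values shown sits.

The compounds shown do not separate a contribution of the methyl itself from the loss of the large group. From the compounds shown here alone, it remains open whether a hydrogen atom, a chlorine atom, an ethyl group or an amine on this aromatic carbon would stand nearer to compound 4 or to compound 2.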